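Benzyloxy for bromo on the aryl of compound 1

The source may hold more compounds than are shown below. What is called first, only, known or untested is meant among the compounds shown, and "the series" means these compounds.

compound 1 `S=C(Nc1ccccc1)N1N=C(c2ccc(Br)cc2)CC1c1ccc2c(c1)OCCO2` — 870 nM
compound 2 `COc1cccc(C2=NN(C(=S)Nc3ccccc3)C(c3ccc4c(c3)OCCO4)C2)c1` — 1380 nM
compound 3 `S=C(Nc1ccccc1)N1N=C(c2ccc(Cl)c(Cl)c2)CC1c1ccc2c(c1)OCCO2` — 58700 nM

In a functional assay on WM 266-4 cells (Homo sapiens) for antiproliferative activity, read by MTT assay, with a stated time of 48 h (a lower number here means a stronger inhibitor of growth, a higher number a weaker inhibitor of growth), compound 1 gives the lowest number of the three, but compound 2 sits close by: a 1.6-fold higher number from compound 1 to compound 2 (0.20 log units; within the scatter). Compound 3 is far from both, as a 67-fold higher number from compound 1 to compound 3 (1.83 log units; beyond the scatter) and a 43-fold higher number from compound 2 to compound 3 (1.63 log units; beyond the scatter) show.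

Compound 4 `S=C(Nc1ccccc1)N1N=C(c2ccc(OCc3ccccc3)cc2)CC1c1ccc2c(c1)OCCO2` arises from compound 1 by a single change: benzyloxy in place of bromo on an aromatic carbon. Among the measured compounds shown here, none of the measured steps exchanges a bromo for a benzyloxy, so they bear on it only loosely. The step from compound 1 to compound 2 shows that swapping one aryl substituent for another can leave this assay almost unchanged, whereas the steps to compound 3 show that a different aryl pattern can cost a great deal. A single group para to a large group, replacing a single halogen, seems closer to the first case than to the second.

Compound 4 is therefore expected to be a somewhat weaker inhibitor than compound 1, with a 2.1-fold higher number from compound 1 to compound 4 (0.32 log units; beyond the scatter) as the estimated step. The estimated value for compound 4 is 1800 nM, with a range from 400 nM to 9000 nM.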

Compound 4, concentration for 50% growth inhibition: 420 nM
The estimate for compound 4 lay 4.3-fold (0.63 log units) above the measured number; low and high end bracket the measured number.
By their numbers in this assay, from the lowest: compound 4; then compounds 1 and 2 (each within the scatter of the next); then compound 3.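

In this assay, benzyloxy in place of bromo gives a 2.1-fold lower number from compound 1 to compound 4 (0.32 log units; beyond the scatter). This aromatic carbon, para to a large group, therefore accepts a substituent that brings its own six-membered aromatic ring, and growth inhibition improves modestly rather than being lost. The earlier compounds had shown no step to a lower number from compound 1, and their aryl changes involved only small substituents, so this is the first sign that a much larger group can be accommodated here; no measurement at hand gives a reason for the gain.

Going by these compounds, it remains open whether the gain comes from the added ring or from the oxygen that links it, which a phenyl or a methoxy at this same carbon would help separate. A longer chain between oxygen and ring, or an amine or a carboxylic acid on the benzyl ring, would show how far this position can be extended.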